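This account rests on a few compounds, and the source may have more. Where it says the series, first, only, none or still open, it means among the compounds named here.

Values measured so far in a physicochemical assay for lipophilicity, read by HPLC, at pH 7.5; a lower number here means a more polar compound, a higher number a more lipophilic compound

Compound 1 `CC[C@@H](Nc1c(C#N)c(-c2ccc(-c3ccccc3N(C)C)cc2)nc2cnccc12)C(N)=O`: 3.2
Compound 2 `CCOc1ccccc1-c1ccc(-c2nc3cnccc3c(N[C@H](CC)C(N)=O)c2C#N)cc1`: 3

Compound 2 and compound 1 lie within the scatter of each other, so neither can be ranked above the other. The change to compound 3 `CC[C@@H](Nc1c(C#N)c(-c2ccc(-c3ccc(Cl)cc3)cc2)nc2cnccc12)C(N)=O` is 4-chlorophenyl in place of 2-ethoxyphenyl on an aromatic carbon in which 4-chlorophenyl takes the place of 2-ethoxyphenyl on an aromatic carbon. Among the measured compounds shown here, the only measured step, a number 0.20 log units lower from compound 1 to compound 2 (within the scatter), is a different exchange, ethoxy in place of dimethylamino, so it guides only loosely. In this assay no shift beyond the scatter is expected, and the estimated step is a number 0.30 log units higher from compound 2 to compound 3 (within the scatter) in size. For compound 3 the estimated value is 3.3 with an expected range from 2.9 to 3.8.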

Compound 3, distribution coefficient: 3.1
Estimate against measurement, compound 3: 0.20 log units above, within the range that was stated.
By their numbers in this assay, from the lowest: compounds 2, 3 and 1 (each within the scatter of the next).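

In this assay, the outer aromatic ring can carry 4-chlorophenyl in place of 2-ethoxyphenyl, giving a number 0.10 log units higher from compound 2 to compound 3 (within the scatter), or in place of 2-(dimethylamino)phenyl, giving a number 0.10 log units lower from compound 1 to compound 3 (within the scatter). Neither the different substituent nor its different placement on the ring produces a step beyond the scatter, so these three compounds cannot be ranked. Nothing available here bears on this result. Still open, going by these compounds, is whether a carboxylic acid or a piperidine at this position would give a step beyond the scatter.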